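The source may report more compounds than this note shows. Statements on the series, on what has been measured and on what is new or still open speak of the compounds shown alone.

Measured in a functional assay on BXPC-3 cells (Homo sapiens) for inhibition, read by MTT assay, with a stated time of 7 days; a higher number here means a weaker inhibitor, a lower number a stronger inhibitor:

- compound 1 `CCN(CC)S(=O)(=O)c1ccc(S(=O)(=O)N2CCC[C@@H](C(=O)N3CCC(O)CC3)C2)cc1`: 4710 nM
- compound 2 `O=C([C@@H]1CCCN(S(=O)(=O)c2ccc(S(=O)(=O)C3COC3)cc2)C1)N1CCC(F)(F)CC1`: 361 nM
- compound 3 `CC(C)S(=O)(=O)c1ccc(S(=O)(=O)N2CCC[C@@H](C(=O)N3CCC(F)(F)CC3)C2)cc1`: 50 nM

Of these three, compound 1 carries the highest number and so is the weakest inhibitor in this assay. Compound 2 lies nearest to it and compound 3 furthest from it, both clearly beyond the scatter.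

The next compound to be tested is compound 4 `CCN(CC)S(=O)(=O)c1ccc(S(=O)(=O)N2CCC[C@@H](C(=O)NC3CCOCC3)C2)cc1`. It differs from compound 1 in a single place: (oxan-4-yl)amino in place of 4-hydroxypiperidin-1-yl on a carbonyl carbon. In words, (oxan-4-yl)amino stands in place of 4-hydroxypiperidin-1-yl on a carbonyl carbon, and the rest of compound 1 is kept.

For the measured compounds named here, only one measured step links two compounds that differ in one place: a 7.2-fold lower number from compound 2 to compound 3 (0.86 log units; beyond the scatter). That step is a sizeable one, but it comes from isopropyl in place of oxetan-3-yl on a sulfonyl sulfur, so it says nothing directly about a change on the carbonyl carbon. Going by the values given here, no measured step covers this change, so the data give no firm direction, and the estimate stays anchored on compound 1 at 4710 nM.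

No shift beyond the scatter is expected, and the estimated step is a 1.3-fold lower number from compound 1 to compound 4 (0.13 log units; within the scatter). For compound 4 the expected value is 3500 nM, with an estimated range of 900 nM to 14000 nM.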

Compound 4, half-maximal inhibitory concentration: 8570 nM
Compound 4: the middle estimate sits 2.4-fold (0.39 log units) below what was measured; measured number inside the range.
By their numbers in this assay, from the lowest: compound 3; then compound 2; then compounds 1 and 4 (each within the scatter of the next).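

For the compounds shown here, the step at the carbonyl carbon in this assay, a 1.8-fold higher number from compound 1 to compound 4 (0.26 log units; within the scatter), is the first measured step at this position, since the only earlier step concerned a group on a sulfonyl sulfur. Here 4-hydroxypiperidin-1-yl and (oxan-4-yl)amino have the same heavy atoms and the same donor and acceptor counts, each with one six-membered non-aromatic ring, yet they are joined differently, and with the rest of compound 1 kept this rearrangement gives no difference that can be told from the scatter. No measurement bears on why the two groups read alike here.

The compounds shown leave open how this carbonyl carbon would respond to a group of a different kind, such as morpholin-4-yl, 4-aminopiperidin-1-yl or a plain dimethylamino group, since the two groups compared here are so closely matched. They also leave open whether the same exchange would read alike with isopropyl on the sulfonyl sulfur, as a single exchange on one background cannot show how far the result carries to another.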